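Compound 1 to compound 4: iodine for a charged group

This account rests on a few compounds, and the source may have more. Where it says the series, first, only, none or still open, it means among the compounds named here.

Compound 1 `COC(=O)C1=C(C)N=C(C)/C(=C(\O)OC)C1c1cccc([N+](C)(C)C)c1` stands at the top of the three measured numbers in a functional assay (muscle tissue) with Cavia porcellus as the target (on this read-out higher numbers stand for an effect only at larger amounts of compound and lower numbers for an effect already at smaller amounts), giving 50100 nM. Its nearest neighbour on that scale is compound 3 `COC(=O)C1=C(C)N=C(C)/C(=C(\O)OC)C1c1cc(Cl)cc(Cl)c1`, which gives 93.3 nM, and the furthest is compound 2 `C=Cc1ccccc1C1C(C(=O)OC)=C(C)N=C(C)/C1=C(\O)OC`, which gives 4.47 nM. Within the data shown here, the only measured step between compounds that differ in one place, a 21-fold higher number from compound 2 to compound 3 (1.32 log units; beyond the scatter), shows that the group on the aryl ring attached to the saturated ring carbon moves the read-out strongly even when both groups are neutral. Compound 4 `COC(=O)C1=C(C)N=C(C)/C(=C(\O)OC)C1c1cccc(I)c1` differs from compound 1 by one iodine atom in place of a group of 4 heavy atoms (3 carbon, 1 nitrogen; no ring), on an aromatic carbon. Among the measured compounds shown here, no measured step exchanges a charged group for a neutral one, so the size of the change has to be read from the three values alone: both neutral aryl groups, in compound 2 and in compound 3, give numbers far lower than compound 1, and compound 3 carries halogens on that same ring. The step from compound 1 to compound 4 is therefore expected to be a large fall, a 1700-fold lower number from compound 1 to compound 4 (3.22 log units; beyond the scatter). For compound 4 a value of 30 nM is estimated, with a range from 5 nM to 200 nM.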

Compound 4, half-maximal effective concentration: 41.7 nM
Compound 4: middle estimate off by 1.4-fold (0.14 log units), on the low side, within the range that was stated.
By their numbers in this assay, from the lowest: compound 2; then compound 4; then compound 3; then compound 1.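

In this assay, among these compounds, a 1200-fold lower number from compound 1 to compound 4 (3.08 log units; beyond the scatter) is the first measured step that replaces the group with a net charge of +1 by an uncharged one, so this single aromatic carbon accounts for a gap far larger than any step among the neutral compounds. With the charged group gone, the 3-iodophenyl compound falls among the neutral aryl compounds: a 2.2-fold lower number from compound 3 to compound 4 (0.35 log units; beyond the scatter) is small though beyond the usual scatter, while a 9.3-fold higher number from compound 2 to compound 4 (0.97 log units; beyond the scatter) is larger, and the 2-vinylphenyl compound keeps the lowest number of the four. No measurement available here bears on why the exchange has so large an effect on this read-out.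

The compounds shown leave open whether the step follows the charge or the particular group, since none of them carries a dimethylamino or tert-butyl group on this aromatic carbon, either of which would keep much of the bulk of the leaving group without its net charge. As far as these compounds go, it also remains open how far iodine itself matters here, as a single chlorine or a methyl group in its place would show.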